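Trimming the Side Chain of Compound 3

The source may hold more compounds than are shown below. What is called first, only, known or untested is meant among the compounds shown, and "the series" means these compounds.

Compound 3 `COc1cc(NC(C)CCCN2C(=O)CN(C(=O)[C@H](N)CC(C)C)C2(C)C)c2ncccc2c1` sits at the bottom of the three solubility numbers. In a physicochemical assay for solubility (on this read-out lower numbers stand for lower solubility and higher numbers for higher solubility), compound 3 gives 26600 ug/mL, while compound 1 `COc1cc(NC(C)CCCN2C(=O)[C@@H](C)N(C(=O)CN)C2(C)C)c2ncccc2c1` gives 110000 ug/mL and compound 2 `COc1cc(NC(C)CCCN2C(=O)CN(C(=O)[C@@H](C)N)C2(C)C)c2ncccc2c1` gives 120000 ug/mL; the gaps from compound 3 to each of the other two lie beyond the scatter. Among the measured compounds shown here, only one measured step bears on the question, a 4.5-fold lower number from compound 2 to compound 3 (0.65 log units; beyond the scatter), described as isopropyl in place of hydrogen on a saturated chain carbon, two bonds along the chain from an amine nitrogen and a carbonyl carbon. Compound 4 `COc1cc(NC(C)CCCN2C(=O)CN(C(=O)[C@H](N)C(C)C)C2(C)C)c2ncccc2c1` differs from compound 3 by isopropyl in place of isobutyl on a saturated chain carbon bound to an amine nitrogen and a carbonyl carbon, a change that removes a single carbon from the chain that was built up in that step. Because a 4.5-fold lower number from compound 2 to compound 3 (0.65 log units; beyond the scatter) accompanied the growth of this chain, partly undoing it is expected to move the number back toward compound 2, though by a smaller amount. The expected step in this assay is a 1.7-fold higher number from compound 3 to compound 4 (0.23 log units; within the scatter). The estimate for compound 4 is 45000 ug/mL, with a range from 22000 ug/mL to 90000 ug/mL.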

Compound 4, solubility: 46500 ug/mL
The estimate for compound 4 lay 1.0-fold (0.01 log units) below the measured number; the measured number falls inside the stated range.
By their numbers in this assay, from the lowest: compounds 3 and 4 (each within the scatter of the next); then compounds 1 and 2 (each within the scatter of the next).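

In this assay, isopropyl in place of isobutyl on this saturated chain carbon gives a 1.7-fold higher number from compound 3 to compound 4 (0.24 log units; within the scatter), so the two side chains cannot be told apart on this read-out. Isopropyl in place of methyl at the same place gives a 2.6-fold lower number from compound 2 to compound 4 (0.41 log units; beyond the scatter), which shows that a gap from compound 2 is already present with isopropyl and does not require the isobutyl of compound 3. No measurement offered here accounts for either step.

What the compounds shown leave open is how an ethyl, a cyclopropyl or a hydroxymethyl group on this saturated chain carbon would read, and where such groups would fall relative to compound 2 and compound 4. Also open, on these data alone, is whether a carboxylic acid or a second amine at this place would give a number closer to that of compound 2.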